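A methyl on the sulfonamide nitrogen of compound 2

The source may hold more compounds than are shown below. What is called first, only, known or untested is meant among the compounds shown, and "the series" means these compounds.

Compound 1 `Cc1cc(COc2ccc(S(=O)(=O)N(C)C3(C(=O)NO)CN(C(=O)C(C)C)C3)cc2)c2ccccc2n1`: 56000000 nM
Compound 2 `Cc1cc(COc2ccc(S(=O)(=O)NC3(C(=O)NO)CN(C(=O)CC(C)C)C3)cc2)c2ccccc2n1`: 5000000 nM

In a physicochemical assay for solubility, with a stated time of 24 h, tested at 30 mg/mL (a higher number here means a more soluble compound, a lower number a less soluble compound), compound 2, at 5000000 nM, is the lower of the two measured compounds. Compound 1 gives 56000000 nM. The gap between these two compounds lies beyond the scatter. Compound 3 `Cc1cc(COc2ccc(S(=O)(=O)N(C)C3(C(=O)NO)CN(C(=O)CC(C)C)C3)cc2)c2ccccc2n1` has methyl in place of hydrogen on a sulfonamide nitrogen. Among the measured compounds shown here, no measured pair isolates this change. Compound 1 also carries methyl there and gives 56000000 nM, but it differs from compound 2 in another place too, so only part of that gap is expected to carry over. A moderate rise beyond the scatter is expected, an estimated 3.2-fold higher number from compound 2 to compound 3 (0.51 log units; beyond the scatter). For compound 3 the estimated value in this assay is 16000000 nM, with an expected range of 5000000 nM to 50000000 nM.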

Compound 3, solubility: 45000000 nM
For compound 3 the middle estimate is 2.8-fold (0.45 log units) below the measured one; low and high end bracket the measured number.
By their numbers in this assay, from the lowest: compound 2; then compounds 3 and 1 (each within the scatter of the next).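

In this assay, methyl in place of hydrogen on a sulfonamide nitrogen can now be read alone, with the isobutyl kept: the change gives a 9.0-fold higher number from compound 2 to compound 3 (0.95 log units; beyond the scatter), a step beyond the scatter. Isobutyl in place of isopropyl on a carbonyl carbon gives a 1.2-fold lower number from compound 1 to compound 3 (0.09 log units; within the scatter), so with methyl on that nitrogen, this second change stays within the scatter. No measurement shown offers a reason for either step. On these data alone, it remains open what ethyl or a longer chain on that sulfonamide nitrogen would give. As far as these compounds go, it is also open whether an amine on the chain at the carbonyl carbon would leave these numbers unchanged.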